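The source may hold more compounds than are shown below. What is called first, only, known or untested is meant among the compounds shown, and "the series" means these compounds.

Measured compounds:
Compound 1 `CC(C)(C)c1ccc(C(=O)Nc2n[nH]c3c2CN(C(=O)c2ccco2)C3)cc1` with 2100 nM in a functional assay on HCT-116 cells (Homo sapiens) for antiproliferative activity; on this read-out lower numbers stand for stronger inhibition and higher numbers for weaker inhibition.
Compound 2 `CCc1cccc(CC)c1NC(=O)N1Cc2[nH]nc(NC(=O)c3ccc(C(C)(C)C)cc3)c2C1` with 2200 nM in this assay.

Compound 1 holds the lowest of the two numbers in this assay, and its nearest neighbour is compound 2, with a 1.0-fold higher number from compound 1 to compound 2 (0.02 log units; within the scatter); the two values cannot be told apart. That one step exchanges the group on the carbonyl carbon, and it leaves the number essentially unchanged.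

Compound 3 `CN1CCN(c2ccc(C(=O)Nc3n[nH]c4c3CN(C(=O)c3ccco3)C4)cc2)CC1` is not yet measured. It differs from compound 1 in one place: 4-methylpiperazin-1-yl in place of tert-butyl on an aromatic carbon. Among the measured compounds shown here, no measured step touches this aromatic carbon, so nothing in the data speaks to the size or direction of such a change. For the measured compounds named here, the only step available, from compound 1 to compound 2, concerns another part of the shared core and shows that at least one substitution elsewhere was tolerated without a shift beyond the scatter.

Without a step bearing on this position, compound 3 is expected to stay near compound 1, with a 1.1-fold lower number from compound 1 to compound 3 (0.02 log units; within the scatter) as the central guess and a wide band around it. The estimate for compound 3 in this assay is therefore 2000 nM, between 400 nM and 10000 nM.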

Compound 3, half-maximal inhibitory concentration: 900 nM
Compound 3: the middle estimate sits 2.2-fold (0.35 log units) above what was measured, within the range that was stated.
By their numbers in this assay, from the lowest: compound 3; then compounds 1 and 2 (each within the scatter of the next).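

At this aromatic carbon, the one position where the shown compounds differ by more than the scatter, 4-methylpiperazin-1-yl in place of tert-butyl gives a 2.3-fold lower number from compound 1 to compound 3 (0.37 log units; beyond the scatter) in this assay, whereas the exchange on the carbonyl carbon gave only a 1.0-fold higher number from compound 1 to compound 2 (0.02 log units; within the scatter). The number at this position therefore responds to the group placed there, if modestly, and it shows that the compact all-carbon tert-butyl is not needed to keep the antiproliferative read-out: a larger group carrying a six-membered non-aromatic ring with hetero atoms is accepted, and the number is lower with it. No measurement shown here gives a reason for this shift.

What the compounds shown leave open is whether the shift belongs to the ring, to its nitrogen atoms or to the terminal methyl, which a piperidine, a morpholine or a piperazine without the methyl at this same aromatic carbon would help to separate. From the compounds shown here alone, it also remains open whether 4-methylpiperazin-1-yl would act the same way with (2,6-diethylphenyl)amino in place of furan-2-yl on the carbonyl carbon.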